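The source may report more compounds than this note shows. Statements on the series, on what has been measured and on what is new or still open speak of the compounds shown alone.

In a functional assay on K562 cells (Homo sapiens) for antiproliferative activity, read by MTT assay, with a stated time of 24 h (a higher number here means a weaker inhibitor, a lower number a stronger inhibitor), three compounds have been measured so far, and each returned only a limit:

- Compound 1 `COc1cccc(/C=C/C(=O)c2ccc(OC)c3c2OC(C)(C)C=C3)c1`: > 10000 nM
- Compound 2 `COc1ccc(C(=O)/C=C/c2ccc(Cl)cc2)c2c1C=CC(C)(C)O2`: > 10000 nM
- Compound 3 `COc1ccc(C(=O)/C=C/c2cccc(Cl)c2)c2c1C=CC(C)(C)O2`: > 10000 nM

Compound 3 therefore has no number, only a limit. Among the measured compounds shown here, the other two compounds offer no number to place it against, and the whole series so far is summed up by the limit of > 10000 nM in this assay, at which 3 of the 3 values shown sit.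

The next compound is compound 4 `COc1ccccc1/C=C/C(=O)c1ccc(OC)c2c1OC(C)(C)C=C2`. It carries 2-methoxyphenyl in place of 3-chlorophenyl on a double-bonded chain carbon bound to a double-bonded chain carbon, and the counted difference is 2-methoxyphenyl in place of 3-chlorophenyl on a double-bonded chain carbon bound to a double-bonded chain carbon.

Two measured changes bear most closely on this one. For the measured compounds named here, the first is a step that the two limits leave unreadable from compound 1 to compound 3, which swaps chloro and methoxy on an aromatic carbon. The second is a step that the two limits leave unreadable from compound 2 to compound 3, which moves to 3-chlorophenyl from 4-chlorophenyl. Neither has a readable size, so neither gives a direction for this assay. The expectation therefore rests only on the three limits, and no step beyond the usual scatter is foreseen, with another limit the likeliest report.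

The expected step is a step that the limit leaves unreadable from compound 3 to compound 4.

Compound 4 is estimated at 12000 nM, with an expected range from 3000 nM to 30000 nM.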

Compound 4, half-maximal inhibitory concentration: > 10000 nM
Compound 4: only a limit was reported; the forecaster's own chance of this, stated with the estimate: 70%; the middle value lies beyond the limit too.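

In this assay compound 4 gives > 10000 nM, which is a limit and not a number. Its steps from compound 1, compound 2 and compound 3 therefore cannot be read: the limit of > 10000 nM in this assay, at which 4 of the 4 values shown sit.

The compounds shown leave open whether these four differ from one another at all in this assay.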